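The compounds below may be only part of what the source reports. "The series", "measured", "known", "first", "only" and "open" are said of these compounds alone.

Measured in a physicochemical assay for solubility, in phosphate buffer, measured as thermodynamic solubility, at pH 7.4; a higher number here means a more soluble compound, a lower number a less soluble compound:
- Compound 1 `CS(=O)(=O)NC(=O)CCc1cn(-c2ccc(Br)cc2)nc1-c1ccccc1`: 200000 nM
- Compound 2 `CS(=O)(=O)NC(=O)CCc1cn(-c2ccc(Br)cc2)nc1-c1ccc([N+](=O)[O-])cc1`: < 5000 nM

Compound 2 stands at < 5000 nM, and this is a limit of the assay, not a number. Its exact place on the scale is therefore unknown.

The next compound, compound 3 `CS(=O)(=O)NC(=O)CCc1cn(-c2ccc(Br)cc2)nc1-c1ccc(N)cc1`, carries amino in place of nitro on an aromatic carbon, para to a large group: amino in place of nitro on an aromatic carbon. It has not yet been measured.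

For the measured compounds named here, only one measured step bears on this change. That step is an at least 40-fold lower number from compound 1 to compound 2 (1.60 log units; beyond the scatter), and it came with nitro in place of hydrogen on an aromatic carbon. Compound 3 no longer carries that nitro, so compound 1, at 200000 nM, is the nearest guide to where it may land. Going by the values given here, no measured step involves amino, so the return may be only partial, or may go further.

A large rise is therefore expected in this assay, estimated as an at least 20-fold higher number from compound 2 to compound 3 (1.30 log units; beyond the scatter). For compound 3 the estimated value is 100000 nM, with an expected range from 20000 nM to 400000 nM.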

Compound 3, solubility: 160000 nM
Beside the measured number, compound 3's estimate is 1.6-fold (0.20 log units) below it; measured number inside the range.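

For the compounds shown here, at this position, on an aromatic carbon para to a large group, the earlier compounds offered only hydrogen and nitro; with amino in place of nitro, this assay gives an at least 32-fold higher number from compound 2 to compound 3 (1.50 log units; beyond the scatter). With amino in place of hydrogen, the same read-out gives a 1.3-fold lower number from compound 1 to compound 3 (0.10 log units; within the scatter), so compound 1 and compound 3 cannot be told apart here, and among the three groups shown at this position, only nitro stands apart from the other two. Compound 2 stands at < 5000 nM, which is a limit of the assay and not a number, so the full size of the step from it stays unknown: the limit of < 5000 nM in this assay, at which 1 of the 3 values shown sits.

The compounds shown leave open whether nitro is alone in this, or whether a nitrile, a carboxylic acid or a methoxy group at this position would read like nitro or like hydrogen and amino. Going by these compounds alone, they also leave open whether the match between amino and hydrogen would hold on another core, or with a longer chain in place of the one shared by these compounds.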